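A few compounds are considered here, and "the series" means these few. Any claim that something is new, unique, unknown or untested is made for them only; others in the source may bear on it.

Compound 1, `CCCNc1nc(=O)c2cc([N+](=O)[O-])cc([N+](=O)[O-])c2s1`, in an ADME assay on Vero cells (Chlorocebus sabaeus) for cytotoxicity, read by MTT assay, with a stated time of 72 h; a lower number here means a stronger inhibitor, a higher number a weaker inhibitor: "not determined" (no result reported)
Compound 2, `CCCCNc1nc(=O)c2cc([N+](=O)[O-])cc([N+](=O)[O-])c2s1`, in this assay: "not determined" (no result reported)
Compound 3, `CCN(CC)c1nc(=O)c2cc(C(F)(F)F)cc([N+](=O)[O-])c2s1`, in this assay: > 100000 nM

Compounds 1 and 2 have no result in this assay. Compound 3 is the only one with an entry, and that entry is a limit of the assay rather than a measured number (the limit of > 100000 nM in this assay, at which 1 of the 3 values shown sits). Compound 4, `O=C(O)C1CCN(c2nc(=O)c3cc(C(F)(F)F)cc([N+](=O)[O-])c3s2)CC1`, differs from compound 3 in one place: 4-carboxypiperidin-1-yl in place of diethylamino on an aromatic carbon. Among the compounds with values here, no step between measured compounds is available, so no size of effect can be read from the data. Compound 4 is expected to stay close to where compound 3 stands, with a step that the limit leaves unreadable from compound 3 to compound 4 that does not go beyond the scatter. The estimate for compound 4 in this assay is 150000 nM, with a range from 40000 nM to 600000 nM.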

Compound 4, half-maximal inhibitory concentration: > 100000 nM
Compound 4: a limit, no number; the forecaster's own chance of this, stated with the estimate: 80%; the middle value lies beyond the limit too.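

Compound 3 and compound 4 both sit at a limit rather than at a number, so no step can be read between them: the limit of > 100000 nM in this assay, at which 2 of the 4 values shown sit.

The compounds shown leave open how far either lies beyond that limit in this assay, and whether 4-carboxypiperidin-1-yl in place of diethylamino changes the result at all.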